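The source may hold more compounds than are shown below. What is called first, only, known or untested is meant among the compounds shown, and "the series" means these compounds.

Measured compounds:
Compound 1 `Cc1ccc(-c2nnc(COc3cnn(C(C)(C)C)c(=O)c3Cl)o2)cc1` — 19.9 ug/mL
Compound 2 `CC(C)(C)n1ncc(OCc2nnc(-c3cc(F)c(Cl)cc3Cl)s2)c(Cl)c1=O` — 67.1 ug/mL
Compound 3 `CCCCn1ncc(OCc2nnc(-c3ccc(F)cc3)o2)c(Cl)c1=O` — 162 ug/mL

Of the compounds shown here, three sharing one core have been tested in a functional assay on the whole organism for inhibition, with Mythimna separata as the target, with a stated time of 5 days; on this read-out higher numbers stand for an effect only at larger amounts of compound and lower numbers for an effect already at smaller amounts. Compound 1 gives the lowest of the three numbers in this assay, and both other compounds lie beyond the usual scatter from it: compound 2 is the nearest, compound 3 the furthest. The three compounds differ from one another in more than one place, so no single change among them can be read as a step.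

Compound 4 `CC(C)(C)n1ncc(OCc2nnc(-c3cccs3)o2)c(Cl)c1=O` has not yet been measured. Compared with compound 1, it carries thiophen-2-yl in place of 4-methylphenyl on an aromatic carbon. Among the measured compounds shown here, no pair of measured compounds isolates a change of this kind, so the size of the step has to be judged from the compound 1 result alone and from the spread seen across compounds 2 and 3. The expected step of a 1.5-fold higher number from compound 1 to compound 4 (0.18 log units; within the scatter) is a slight rise in the number, most likely not beyond the scatter. On that basis compound 4 is estimated at 30 ug/mL, with a range from 12 ug/mL to 80 ug/mL.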

Compound 4, half-maximal effective concentration: > 300 ug/mL
Compound 4 ended at the assay's limit (the forecaster's own chance of this, stated with the estimate: 10%); middle value at least 10-fold (1.00 log units) from the limit.
By their numbers in this assay, from the lowest: compound 1; then compound 2; then compound 3. At a limit, above all of these: compound 4.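

In this assay, among the compounds shown here, the group on this aromatic carbon of the five-membered aromatic ring with 2 nitrogen and 1 oxygen proves decisive in a way the earlier compounds could not show, as they differ from one another in more than one place: thiophen-2-yl in place of 4-methylphenyl gives an at least 15-fold higher number from compound 1 to compound 4 (1.17 log units; beyond the scatter) and this single change is large and beyond the scatter. Compound 4 reads > 300 ug/mL and this is a limit of the assay, not a number. Compounds 1, 2 and 3 all gave numbers, so this is the first result that cannot be placed on the scale, and how far compound 4 lies past that point stays unread: the limit of > 300 ug/mL in this assay, at which 1 of the 4 values shown sits.

The compounds shown leave open whether the step follows from the thiophen-2-yl ring itself or from the loss of the six-membered ring with its methyl group. Plain phenyl, furan-2-yl or 5-methylthiophen-2-yl on this same carbon, with the rest of compound 1 kept, would separate these readings in this assay and show whether any five-membered ring can hold a measurable effect here.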